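The source may hold more compounds than are shown below. What is called first, only, known or untested is meant among the compounds shown, and "the series" means these compounds.

In an ADME assay on microsomes from liver (Mus musculus) for metabolic stability, read by HPLC, using NADPH, with a stated time of 60 min, tested at 1 uM, in the presence of a further agent that is not named here (a higher number here means that the compound lasts longer, a lower number that the compound disappears faster), compound 1 `O=C(NNS(=O)(=O)c1ccccc1F)c1cc(F)cc(-n2cccn2)c1` gives 0.0833 h and compound 3 `O=C(NNS(=O)(=O)c1ccccc1F)c1cccc(-n2cccn2)c1` gives 0.167 h. Among the measured compounds shown here, the one measured step is a 2.0-fold higher number from compound 1 to compound 3 (0.30 log units; within the scatter); it lies within the scatter and sits elsewhere in the structure, on an aromatic carbon. Compound 2 `Cc1cc(OC(C)C)cc(C(=O)NNS(=O)(=O)c2ccccc2F)c1` gives < 0.0334 h, which is a limit and not a number. Compound 4 `CCOc1cc(C)cc(C(=O)NNS(=O)(=O)c2ccccc2F)c1` differs from it by hydrogen in place of methyl on a saturated chain carbon bound to an oxygen on an aromatic ring and a saturated chain carbon, that is, isopropoxy to ethoxy. For the measured compounds named here, no measured step changes the isopropoxy group, so the only guide is a 2.0-fold higher number from compound 1 to compound 3 (0.30 log units; within the scatter), and no step beyond the scatter is expected in this assay. The estimated step is an at least 1.1-fold higher number from compound 2 to compound 4 (0.07 log units; that floor lies within the scatter). For compound 4 the expected half-life is 0.04 h, with an estimated range of 0.02 h to 0.09 h.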

Compound 4, half-life in the Mus musculus assay: < 0.0334 h
Compound 4 was reported as a limit; the forecaster's own chance of this, stated with the estimate: 55%; middle value at least 1.1-fold (0.07 log units) away from the limit.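

In the Mus musculus assay compound 2 is reported only as a limit of < 0.0334 h. In the Mus musculus assay compound 4 is likewise reported only as a limit of < 0.0334 h. Among the compounds shown here, no step between them can be read: the limit of < 0.0334 h in the Mus musculus assay, at which 2 of the 4 values shown sit. The compounds shown leave open whether isopropoxy to ethoxy alters the half-life at all. In a physicochemical assay for solubility, read by nephelometry, in phosphate buffer, measured as kinetic solubility, at pH 6.5 (on this read-out lower numbers stand for lower solubility and higher numbers for higher solubility), compound 2 gives 12.5 ug/mL and compound 4 gives 12.5 ug/mL with no change at the digits printed from compound 2 to compound 4 (within the scatter).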